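The source may report more compounds than this note shows. Statements on the series, on what has been measured and on what is new or still open speak of the compounds shown alone.

Within the data shown here, in a functional assay on HCT-8 cells (Homo sapiens) for cytotoxicity (on this read-out higher numbers stand for an effect only at larger amounts of compound and lower numbers for an effect already at smaller amounts), compound 1 `CC(C)Oc1cc(-c2ccccc2)nc2ccccc12` gives 10 ug/mL, the only true number so far. Compound 2 `Oc1cc(-c2ccccc2)nc2c(O)cccc12` gives > 10 ug/mL, which is a limit of the assay and not a number. Among the measured compounds shown here, no pair of measured compounds differs in one place, so the series offers no measured step to scale from.

Compound 3 `CS(=O)(=O)Oc1cc(-c2ccccc2)nc2ccccc12` keeps the core of compound 1 and carries methylsulfonyl in place of isopropyl on an oxygen on an aromatic ring. The same difference reads isopropoxy to (methylsulfonyl)oxy. The only numerical anchor in this assay is compound 1 at 10 ug/mL, so no step beyond the usual scatter is expected, in either direction. The estimated step is no change at the digits printed from compound 1 to compound 3 (within the scatter). For compound 3 the expected value is 10 ug/mL, with an estimated range from 4 ug/mL to 25 ug/mL.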

Compound 3, half-maximal effective concentration: 5.6 ug/mL
The estimate for compound 3 lay 1.8-fold (0.25 log units) above the measured number, within the range that was stated.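

Replacing isopropyl with methylsulfonyl on an oxygen on an aromatic ring gives a 1.8-fold lower number from compound 1 to compound 3 (0.25 log units; within the scatter) in this assay. Among these compounds, this is the first measured step, and it gives a first reading at this position. The read-out stays within the scatter whether the oxygen carries isopropyl, an all-carbon group with no hydrogen-bond acceptors, or methylsulfonyl, which brings sulfur and two hydrogen-bond acceptors.

This single exchange leaves open whether an amine, a carboxylic acid or a longer chain on that oxygen would keep the read-out in the same range, and whether any group there would move it beyond the scatter. Compound 2 remains a limit of the assay and not a number, so it gives no step, and the series has this upper bound: the limit of > 10 ug/mL in this assay, at which 1 of the 3 values shown sits.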